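Nitro in Place of Hydrogen in a Benzamide Series

A few compounds are considered here, and "the series" means these few. Any claim that something is new, unique, unknown or untested is made for them only; others in the source may bear on it.

Compound 1 `Cc1cc(NC(=O)c2ccc(Cl)cc2)ccc1NS(=O)(=O)C(F)(F)F` in an ADME assay on HEK293 cells (Homo sapiens) for cytotoxicity, read by MTT assay, with a stated time of 48 h (a higher number here means a weaker inhibitor, a lower number a stronger inhibitor), gives 201000 nM. Compound 2 `Cc1cc(NC(=O)c2ccc(Cl)c([N+](=O)[O-])c2)ccc1NS(=O)(=O)C(F)(F)F` in this assay gives > 250000 nM, and this value is a limit of the assay rather than a number. The change between them is nitro in place of hydrogen on an aromatic carbon, and it produced an at least 1.2-fold higher number from compound 1 to compound 2 (0.09 log units; that floor lies within the scatter). In reading that step it matters that (the limit of > 250000 nM in this assay, at which 1 of the 3 values shown sits).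

Going by the values given here, compound 3 `CCS(=O)(=O)Nc1ccc(NC(=O)c2ccc(Cl)cc2)cc1F` in this assay gives 53400 nM, the lowest of the two numbers so far; how its core differs from the core of compound 1 is not broken down here. Compound 4 `CCS(=O)(=O)Nc1ccc(NC(=O)c2ccc(Cl)c([N+](=O)[O-])c2)cc1F` carries the same change relative to compound 3, namely (nitro in place of hydrogen on an aromatic carbon).

Since the earlier step of an at least 1.2-fold higher number from compound 1 to compound 2 (0.09 log units; that floor lies within the scatter) only sets a floor that lies within the usual scatter, the corresponding step is expected to be modest, at a 1.6-fold higher number from compound 3 to compound 4 (0.20 log units; within the scatter), with some room for a larger rise because compound 2 reached the assay limit. Compound 4 is therefore expected to give 85000 nM, within a range from 35000 nM to 220000 nM in this assay.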

Compound 4, half-maximal inhibitory concentration: 83700 nM
Compound 4: middle estimate off by 1.0-fold (0.01 log units), on the high side, within the range that was stated.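

In this assay, nitro in place of hydrogen on an aromatic carbon, ortho to a chloro group, gave a 1.6-fold higher number from compound 3 to compound 4 (0.20 log units; within the scatter), so on this core the change shifts the number by no more than the usual scatter of repeated measurements. Set beside the earlier step, the two results can be compared only so far: the same change on two cores in this assay, an at least 1.2-fold higher number (0.09 log units; that floor lies within the scatter) from compound 1 to compound 2 and a 1.6-fold higher number (0.20 log units; within the scatter) from compound 3 to compound 4; the limit leaves it open whether they differ The pair shows that the change did not move the number beyond the scatter on the core of compound 3, but it does not show that the change acts alike on the core of compound 1, where compound 2 gives > 250000 nM, a limit of the assay and not a number.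

The compounds shown leave open whether an amine or a carboxylic acid on the same aromatic carbon would give a similarly small step in this assay. They also leave open which of the several differences between the two cores accounts for the gap in their printed values.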